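From Nitro to Amino on the Aryl Substituent

The compounds below may be only part of what the source reports. "The series", "measured", "known", "first", "only" and "open" are said of these compounds alone.

For the measured compounds named here, compound 2 `CCOC(=O)c1cn(Cc2ccccc2F)c2cc(-c3ccc([N+](=O)[O-])cc3)c(CN(C)Cc3ccccc3)n2c1=O` gives 450 nM in an assay on HEK293 cells for binding affinity to Gonadotropin-releasing hormone receptor (Homo sapiens), read by radioligand binding (a lower number here means a stronger inhibitor, a higher number a weaker inhibitor), the highest of the two numbers measured so far; its nearest neighbour is compound 1 `CCOC(=O)c1cn(Cc2ccccc2F)c2cc(-c3ccc(OC)cc3)c(CN(C)Cc3ccccc3)n2c1=O`, which in this assay gives 400 nM. Going by the values given here, the single measured step, a 1.1-fold higher number from compound 1 to compound 2 (0.05 log units; within the scatter), keeps the two within the usual scatter. Compound 3 `CCOC(=O)c1cn(Cc2ccccc2F)c2cc(-c3ccc(N)cc3)c(CN(C)Cc3ccccc3)n2c1=O` has not yet been measured. The change from compound 2 to compound 3 is amino in place of nitro on an aromatic carbon. Among the compounds with values here, only one measured step bears on it, and only loosely: it concerns the same aromatic carbon, with nitro in place of methoxy, and it was too small to separate from the scatter. Within the data shown here, no measured pair shows what amino does there. Because the earlier exchange at this carbon, a 1.1-fold higher number from compound 1 to compound 2 (0.05 log units; within the scatter), hardly moved the number, the expected step here is a 1.1-fold lower number from compound 2 to compound 3 (0.05 log units; within the scatter), with no direction that should rise above the scatter. The estimate for compound 3 in this assay is therefore 400 nM, within a range from 150 nM to 1100 nM.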

Compound 3, inhibition constant: 190 nM
Estimate against measurement, compound 3: 2.1-fold (0.32 log units) above; the range from low to high includes it.
By their numbers in this assay, from the lowest: compound 3; then compounds 1 and 2 (each within the scatter of the next).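

In this assay, going from 4-nitrophenyl to 4-aminophenyl gives a 2.4-fold lower number from compound 2 to compound 3 (0.37 log units; beyond the scatter), so this aromatic carbon, para to a large group, does respond to what stands on it, which the exchange of methoxy for nitro had not shown. The amino group also separates from methoxy, with a 2.1-fold lower number from compound 1 to compound 3 (0.32 log units; beyond the scatter), so compound 3 stands apart from both earlier compounds, while these two remain within the scatter of each other and the change is seen for amino alone. Amino brings a hydrogen-bond donor that nitro lacks, but nothing measured here links that difference, or any other, to the lower number.

The compounds shown leave open whether a methylamino group, a dimethylamino group, an acetamido group or a hydroxyl group on this same carbon would stay close to compound 3 or return to the level of compound 1 and compound 2. They also leave open whether amino would give a step of similar size if another part of the shared core were changed.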